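Swapping Nitro for Trifluoromethyl on a Weak Antiproliferative Scaffold

The source may hold more compounds than are shown below. What is called first, only, known or untested is meant among the compounds shown, and "the series" means these compounds.

Among the compounds with values here, compound 1 `CC1=CSC(O)(c2cccc([N+](=O)[O-])c2)c2noc(=O)n21` was tested in a functional assay on A2780/DX3 cells (Homo sapiens) for antiproliferative activity, read by MTT assay, with a stated time of 3 days (on this read-out higher numbers stand for weaker inhibition and lower numbers for stronger inhibition), where compound 1 gives 129000 nM, the only actual number among the values shown. Compound 2 `CCCCCOC1(c2ccc(Cl)cc2)SC=C(C)n2c1noc2=O` in this assay reaches only a limit, > 100000 nM, and the limit of > 100000 nM in this assay, at which 1 of the 2 values shown sits, marks that edge of the measurement. Compound 3 `CC1=CSC(O)(c2cccc(C(F)(F)F)c2)c2noc(=O)n21` differs from compound 1 in one place: trifluoromethyl in place of nitro on an aromatic carbon. Within the data shown here, no measured step follows such a swap here. The step from compound 1 to compound 3 is expected to stay within the usual scatter, a 1.2-fold higher number from compound 1 to compound 3 (0.07 log units; within the scatter). Compound 3 is estimated at 150000 nM, between 50000 nM and 400000 nM.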

Compound 3, half-maximal inhibitory concentration: 71000 nM
For compound 3 the middle estimate is 2.1-fold (0.32 log units) above the measured one, within the range that was stated.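

The step is a 1.8-fold lower number from compound 1 to compound 3 (0.26 log units; within the scatter) and so, in this assay, nitro and trifluoromethyl on this aromatic carbon cannot be told apart. The hydrogen-bond acceptors of nitro, absent from trifluoromethyl, are therefore not needed to hold this weak level of activity. No measured property here explains why the two groups match.

From the compounds shown here alone, whether an amine or a carboxylic acid on this same carbon would move the number beyond the scatter stays open. So does the effect of a longer chain elsewhere on the shared core.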